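The source may hold more compounds than are shown below. What is called first, only, known or untested is meant among the compounds shown, and "the series" means these compounds.

Of the compounds shown here, three have so far been measured in an assay on HEK293 cells for inhibition of transient receptor potential cation channel subfamily V member 1 (Homo sapiens), read by FLIPR, at pH 5.5; on this read-out lower numbers stand for stronger inhibition and higher numbers for weaker inhibition. Compound 1 `Cc1ccc(N2CCN(C(=O)Nc3nc4ccc(F)cc4s3)CC2)nn1` gives > 10000 nM, which is a limit of the assay and not a number. Compound 2 `Cc1cc(N2CCN(C(=O)Nc3ccc(C(C)C)cc3)CC2)nnc1Cl` gives > 10000 nM, again a limit. Compound 3 `Cc1cc(N2CCN(C(=O)Nc3ccc(OC(F)(F)F)cc3)CC2)nnc1Cl` gives > 10000 nM, also a limit. Within the data shown here, the one measured step, a step that the two limits leave unreadable from compound 2 to compound 3, puts trifluoromethoxy in place of isopropyl on an aromatic carbon, and its size cannot be read. Compound 3 thus stands at the limit with the other two, as the limit of > 10000 nM in this assay, at which 3 of the 3 values shown sit, shows. Compound 4 `Cc1cnnc(N2CCN(C(=O)Nc3ccc(OC(F)(F)F)cc3)CC2)c1` differs from compound 3 in one place: hydrogen in place of chloro on an aromatic carbon. Among the measured compounds shown here, no measured step removes a chloro, so none bears on this change directly; the only guide is that every value so far sits at the limit. The expected step in this assay is therefore a step that the limit leaves unreadable from compound 3 to compound 4, nothing beyond scatter in either direction. Compound 4 is estimated at 15000 nM, within a range from 5000 nM to 50000 nM, and the assay would most probably again report only a limit.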

Compound 4, half-maximal inhibitory concentration: > 10000 nM
Compound 4 gave a limit, no number; the forecaster's own chance of this, stated with the estimate: 75%; the middle value does not contradict the limit.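

Compound 3 and compound 4 both give only a limit of the assay, so the step that puts hydrogen in place of chloro cannot be read. The compounds shown leave open how strongly any of them inhibits, and which change would yield a real number: the limit of > 10000 nM in this assay, at which 4 of the 4 values shown sit.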